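Acetoxy on the side chain of compound 2

This account rests on a few compounds, and the source may have more. Where it says the series, first, only, none or still open, it means among the compounds named here.

Two compounds of the shared core have numbers in a functional assay on HT-29 cells (Homo sapiens) for cytotoxicity, read by MTT assay, with a stated time of 48 h; on this read-out higher numbers stand for weaker inhibition and lower numbers for stronger inhibition. Compound 1 `CC(C)=CC[C@H](OC(=O)C=C(C)C)C1=CC(=O)c2c(O)ccc(O)c2C1=O` gives 800 nM in this assay. Compound 2 `COc1ccc(O)c2c1C(=O)C=C(CCC=C(C)C)C2=O` gives 5090 nM in this assay, the highest of the two numbers, with compound 1 as its nearest neighbour; the two differ in more than one place, so only their values are set side by side. Compound 3 `COc1ccc(O)c2c1C(=O)C=C([C@H](CC=C(C)C)OC(C)=O)C2=O` is not yet measured; it differs from compound 2 by acetoxy in place of hydrogen on a saturated chain carbon bound to a double-bonded ring carbon and a saturated chain carbon. For the measured compounds named here, no single-change step is in hand. A moderate drop in the number is expected, in the direction of compound 1 with its 800 nM. Compound 3 is thus estimated at 2500 nM, within 900 nM to 7000 nM, a step of a 2.0-fold lower number from compound 2 to compound 3 (0.31 log units; beyond the scatter) expected to reach beyond the scatter.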

Compound 3, half-maximal inhibitory concentration: 620 nM
Beside the measured number, compound 3's estimate is 4.0-fold (0.61 log units) above it, outside the stated range (below it).
By their numbers in this assay, from the lowest: compounds 3 and 1 (each within the scatter of the next); then compound 2.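

In this assay, acetoxy in place of hydrogen on a saturated chain carbon bound to a double-bonded ring carbon and a saturated chain carbon gives an 8.2-fold lower number from compound 2 to compound 3 (0.91 log units; beyond the scatter) as a single change. For the compounds shown here, this is the first step that isolates one place, and it shows that this chain carbon can carry acetoxy with a lower number as the result.

As far as these compounds go, whether a hydroxyl or a longer acyl group such as butyryloxy on this carbon would give a similar number remains open. No measurement at hand gives a reason for this step.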